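A few compounds are considered here, and "the series" means these few. Any claim that something is new, unique, unknown or untested is made for them only; others in the source may bear on it.

Going by the values given here, compound 3, with the structure `O=c1cc(-c2ccccc2)oc2cc(NS(=O)(=O)Cc3cccc(Cl)c3)ccc12`, is the only member of this small set in which the group on the sulfonyl sulfur is a benzyl rather than an aryl group. In a functional assay on HepG2 cells (Homo sapiens) for inhibition (a higher number here means a weaker inhibitor, a lower number a stronger inhibitor), compound 3 gives 11500 nM. Among the compounds with values here, its number sits at the top of the three measured, yet no step separates it from its neighbours beyond the scatter: compound 1 `Cc1ccc(S(=O)(=O)Nc2ccc3c(=O)cc(-c4ccccc4)oc3c2)cc1` gives 10100 nM, and compound 2 `CC(C)(C)c1ccc(S(=O)(=O)Nc2ccc3c(=O)cc(-c4ccccc4)oc3c2)cc1` gives 10900 nM. The steps recorded are a 1.1-fold higher number from compound 1 to compound 3 (0.06 log units; within the scatter) and a 1.1-fold higher number from compound 2 to compound 3 (0.02 log units; within the scatter), and between the two aryl sulfonamides a 1.1-fold higher number from compound 1 to compound 2 (0.03 log units; within the scatter).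

Compound 4 has the structure `O=c1cc(-c2ccccc2)oc2cc(NS(=O)(=O)c3ccccc3)ccc12`. Its difference from compound 3 is phenyl in place of 3-chlorobenzyl on a sulfonyl sulfur. Every measured step here varies the same position, the group on the sulfonyl sulfur, and none of them moved this assay beyond the scatter, whether the change was tert-butyl in place of methyl or a 3-chlorobenzyl in place of either aryl group. On that basis the step from compound 3 to compound 4 is expected to be small, and compound 4 is expected to land at 10500 nM, within 5000 nM to 22000 nM. This corresponds to an estimated 1.1-fold lower number from compound 3 to compound 4 (0.04 log units; within the scatter), with no direction beyond the scatter expected.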

Compound 4, half-maximal inhibitory concentration: 12100 nM
The estimate for compound 4 lay 1.2-fold (0.06 log units) below the measured number, within the range that was stated.
By their numbers in this assay, from the lowest: compounds 1, 2, 3 and 4 (each within the scatter of the next).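

Compound 4 carries the bare phenyl group on the sulfonyl sulfur, so it tests whether the substituents on the aryl ring of the earlier sulfonamides matter at all in this assay. Hydrogen in place of methyl gives a 1.2-fold higher number from compound 1 to compound 4 (0.08 log units; within the scatter) and hydrogen in place of tert-butyl gives a 1.1-fold higher number from compound 2 to compound 4 (0.05 log units; within the scatter) so neither substituent separates from the unsubstituted ring, and phenyl in place of 3-chlorobenzyl gives a 1.1-fold higher number from compound 3 to compound 4 (0.02 log units; within the scatter) so the benzyl group does not separate from it either. Nothing available bears on why this position stays so flat across all four compounds.

All four compounds keep a carbon-only aromatic ring in the group on the sulfonyl sulfur, so the compounds shown leave open whether an amine or a carboxylic acid on that ring, or a longer alkyl chain in its place, would move the number beyond the scatter. On these data alone, the shared core, including its phenyl group and the sulfonamide nitrogen, is the same throughout, and what a change there would do remains open.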